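Swapping the Sulfonyl Aryl Group: From Methoxy to Chloro

The source may hold more compounds than are shown below. What is called first, only, known or untested is meant among the compounds shown, and "the series" means these compounds.

Of the compounds shown here, three built on a shared core have been tested so far in an assay on cells for inhibition of HSP60/HSP10 (Homo sapiens), with a stated time of 60 min; a lower number here means a stronger inhibitor, a higher number a weaker inhibitor. Compound 1 `O=S(=O)(Nc1ccc(-c2nc3ccccc3o2)cc1)c1ccccc1Cl` reaches only the limit of this assay, giving > 100000 nM. Compound 2 `O=S(=O)(Nc1ccc(-c2nc3ccccc3o2)cc1)c1ccccc1O` likewise sits at the limit, with > 100000 nM. Compound 3 `COc1ccccc1S(=O)(=O)Nc1ccc(-c2nc3ccccc3o2)cc1` also stops at the limit, at > 100000 nM. Because all three values sit at the limit of > 100000 nM in this assay, at which 3 of the 3 values shown sit, none of the steps between them can be read: a step that the two limits leave unreadable from compound 1 to compound 2, a step that the two limits leave unreadable from compound 1 to compound 3 and a step that the two limits leave unreadable from compound 2 to compound 3. Compound 3 therefore stands where every measured compound stands, at the limit and no further.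

Compound 4 `O=S(=O)(Nc1ccc(-c2nc3ccccc3o2)cc1)c1ccc(Cl)cc1` differs from compound 3 by 4-chlorophenyl in place of 2-methoxyphenyl on a sulfonyl sulfur. Within the data shown here, no measured step gives a readable size, so there is no basis for foreseeing a step beyond the scatter in this assay, in either direction. Compound 4 is accordingly expected to remain at the limit, with an estimate of 100000 nM and a range from 20000 nM to 500000 nM. This estimate means an expected step of a number no higher from compound 3 to compound 4 (the limit leaves the size open).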

Compound 4, half-maximal inhibitory concentration: 61000 nM
For compound 4 the middle estimate is 1.6-fold (0.21 log units) above the measured one, within the range that was stated.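

Among these compounds, compound 4, with 4-chlorophenyl on the sulfonyl sulfur, is the only one of the four compounds to give a number rather than a limit in this assay. The change gives an at least 1.6-fold lower number from compound 3 to compound 4 (0.21 log units; that floor lies within the scatter), an at least 1.6-fold lower number from compound 2 to compound 4 (0.21 log units; that floor lies within the scatter) and an at least 1.6-fold lower number from compound 1 to compound 4 (0.21 log units; that floor lies within the scatter), the last of these being a change from 2-chlorophenyl to 4-chlorophenyl, so even the compound with the same kind of atoms on its phenyl ring stays at the limit. Each step is only a floor, and its true size stays open because the other values are limits: the limit of > 100000 nM in this assay, at which 3 of the 4 values shown sit.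

Whether the steps really exceed the scatter cannot be told from these compounds. Going by these compounds, it also remains open whether an amine or a carboxylic acid in place of the chloro of compound 4 would keep a measurable number in this assay.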